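Working notes on four analogues in a cell growth series

The source may report more compounds than this note shows. Statements on the series, on what has been measured and on what is new or still open speak of the compounds shown alone.

Measured so far:
compound 1, `O=C(/C=C/c1ccc(OCc2cn(Cc3cccc(F)c3)nn2)cc1)c1ccc(Br)cc1`: in a functional assay on MCF7 cells (Homo sapiens) for inhibition, read by MTT assay, with a stated time of 48 h, tested at 10 uM (on this read-out higher numbers stand for more inhibition of growth at the one concentration tested and lower numbers for less inhibition of growth), compound 1 gives 42%.
compound 2, `O=C(/C=C/c1ccc(OCc2cn(Cc3ccc(F)cc3)nn2)cc1)c1ccc(Br)cc1`: in this assay compound 2 gives 37%.
compound 3, `COc1ccc(C(=O)/C=C/c2ccc(OCc3cn(Cc4cccc(F)c4)nn3)cc2)cc1`: in this assay compound 3 gives 41%.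

The two cores differ by methoxy in place of bromo on an aromatic carbon, and this change gives a number 1 percentage points lower from compound 1 to compound 3 (within the scatter). Within the core of compound 1, the change 4-fluorophenyl in place of 3-fluorophenyl on a saturated chain carbon bound to an aromatic nitrogen gives a number 5 percentage points lower from compound 1 to compound 2 (within the scatter).

Compound 4, `COc1ccc(C(=O)/C=C/c2ccc(OCc3cn(Cc4ccc(F)cc4)nn3)cc2)cc1`, is not yet measured in this assay. Going by the values given here, it differs from compound 3 by 4-fluorophenyl in place of 3-fluorophenyl on a saturated chain carbon bound to an aromatic nitrogen, the same change as the one from compound 1 to compound 2, at the same place.

The expected step is a number 5 percentage points lower from compound 3 to compound 4 (within the scatter), resting on the earlier step of a number 5 percentage points lower from compound 1 to compound 2 (within the scatter) for the same change. Compound 4 is therefore estimated at 36%, with a range from 26% to 46%.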

Compound 4, percent growth inhibition at one concentration: 15%
Compound 4: the middle estimate sits 21 percentage points above what was measured; the whole stated range lies above it.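

The change from 3-fluorophenyl to 4-fluorophenyl does not carry over unchanged between the two cores in this assay. On the core of compound 3 it gives a number 26 percentage points lower from compound 3 to compound 4 (beyond the scatter), and the two steps for this change differ: the same change on two cores in this assay, a number 5 percentage points lower (within the scatter) from compound 1 to compound 2 and a number 26 percentage points lower (beyond the scatter) from compound 3 to compound 4, 21 percentage points apart, beyond the scatter of two such steps. Read the other way, methoxy in place of bromo gives a number 22 percentage points lower from compound 2 to compound 4 (beyond the scatter), which also departs from its earlier step, so the two changes do not add up across these four compounds, though this single set shows neither why nor whether other cores behave alike: the same change on two cores in this assay, a number 1 percentage points lower (within the scatter) from compound 1 to compound 3 and a number 22 percentage points lower (beyond the scatter) from compound 2 to compound 4, 21 percentage points apart, beyond the scatter of two such steps.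

Still open, on these data alone, is how the fluorophenyl change behaves with another group on the aromatic carbon now holding bromo or methoxy, such as an amine or a carboxylic acid. Also open, as far as these compounds go, is whether a longer chain in place of the saturated chain carbon bound to an aromatic nitrogen gives the same result.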